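Chloro step transferred onto the carbamoylmethyl core

The source may hold more compounds than are shown below. What is called first, only, known or untested is meant among the compounds shown, and "the series" means these compounds.

Compound 1 `C[C@H](Nc1cc(=O)oc2cc(OCc3ccccc3)ccc12)C(N)=O` is the reference of the series. In an assay for inhibition of Amine oxidase [flavin-containing] B (Rattus norvegicus) (a lower number here means a stronger inhibitor, a higher number a weaker inhibitor), compound 1 gives 680 nM. Compound 2 `C[C@H](Nc1cc(=O)oc2cc(OCc3cccc(Cl)c3)ccc12)C(N)=O` carries the change (chloro in place of hydrogen on an aromatic carbon); in this assay compound 2 gives 210 nM, and the step is a 3.2-fold lower number from compound 1 to compound 2 (0.51 log units; beyond the scatter). Compound 3 `NC(=O)Cc1cc(=O)oc2cc(OCc3ccccc3)ccc12` differs from compound 1 in the core, (carbamoylmethyl in place of (1-carbamoylethyl)amino on an aromatic carbon); in this assay compound 3 gives 200 nM, the step being a 3.4-fold lower number from compound 1 to compound 3 (0.53 log units; beyond the scatter). Compound 3 and compound 2 lie within the scatter of each other, so no order between them is read. Compound 4 `NC(=O)Cc1cc(=O)oc2cc(OCc3cccc(Cl)c3)ccc12` is not yet measured. Its difference from compound 3 is chloro in place of hydrogen on an aromatic carbon, and the place is described in the same words as for the change from compound 1 to compound 2, so it is the same change, occurring for the second time in the series, now on the core of compound 3. A step of similar size is expected, a 2.9-fold lower number from compound 3 to compound 4 (0.46 log units; beyond the scatter), because the earlier step of a 3.2-fold lower number from compound 1 to compound 2 (0.51 log units; beyond the scatter) lay beyond the scatter. Compound 4 is therefore estimated at 70 nM in this assay, with a range from 30 nM to 160 nM. This rests on a single earlier pair, so the range is kept wide.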

Compound 4, half-maximal inhibitory concentration: 30 nM
For compound 4 the middle estimate is 2.3-fold (0.37 log units) above the measured one; measured number inside the range.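

In this assay the chloro change keeps its direction on the carbamoylmethyl core, with a 6.7-fold lower number from compound 3 to compound 4 (0.82 log units; beyond the scatter), and its size on the two cores does not separate: the same change on two cores in this assay, a 3.2-fold lower number (0.51 log units; beyond the scatter) from compound 1 to compound 2 and a 6.7-fold lower number (0.82 log units; beyond the scatter) from compound 3 to compound 4, 2.1-fold (0.31 log units) apart, within the scatter of two such steps

The core change likewise keeps its direction on the 3-chlorobenzyl compounds, with a 7.0-fold lower number from compound 2 to compound 4 (0.85 log units; beyond the scatter), and again the two steps do not separate: the same change on two cores in this assay, a 3.4-fold lower number (0.53 log units; beyond the scatter) from compound 1 to compound 3 and a 7.0-fold lower number (0.85 log units; beyond the scatter) from compound 2 to compound 4, 2.1-fold (0.31 log units) apart, within the scatter of two such steps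

Across these four compounds, the two changes therefore behave as independent within the scatter, but this rests on a single closed set of two cores and two benzyl groups, so it does not show that either change would carry over in the same way to any other core or benzyl group.

Still open, going by these compounds, is whether a bromo or a methoxy group in place of the chloro would give a step of this kind on both cores. Also open, on these data alone, is whether the chloro step would persist with a carboxylic acid or a longer chain in place of the carbamoylmethyl.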